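Furanyl Chalcone Benzoxaborole and Cytotoxicity in Mouse Fibroblasts

The source may report more compounds than this note shows. Statements on the series, on what has been measured and on what is new or still open speak of the compounds shown alone.

Three chalcone-type benzoxaboroles were tested in an ADME assay on L929 cells (Mus musculus) for cytotoxicity, read by resazurin assay, with a stated time of 72 h; a lower number here means a stronger inhibitor, a higher number a weaker inhibitor. Compound 1 `O=C(/C=C/c1ccc2c(c1)B(O)OC2)c1ccc(Cl)c(Cl)c1` reached only the assay limit, giving > 10 ug/mL. Compound 2 `O=C(/C=C/c1ccc2c(c1)B(O)OC2)c1ccc(I)cc1` likewise gave the limit > 10 ug/mL. Compound 3 `COc1ccc(C(=O)/C=C/c2ccc3c(c2)B(O)OC3)cc1OC` also sat at the limit, > 10 ug/mL. Thus compound 2 stands where every measured compound stands, namely at the limit of > 10 ug/mL in this assay, at which 3 of the 3 values shown sit, so no step between measured compounds can be read. Compound 4 `O=C(/C=C/c1ccc2c(c1)B(O)OC2)c1ccco1` is not yet measured, and it differs from compound 2 by furan-2-yl in place of 4-iodophenyl on a carbonyl carbon. With every known value at the limit, no shift beyond the usual scatter is expected for this change, and the step that the limit leaves unreadable from compound 2 to compound 4 is estimated to be flat. Compound 4 is expected to give about 15 ug/mL in this assay, within 7 ug/mL to 40 ug/mL, most likely again reported only as a limit.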

Compound 4, half-maximal inhibitory concentration: > 10 ug/mL
Compound 4: a limit, no number; the forecaster's own chance of this, stated with the estimate: 75%; the middle value lies beyond the limit too.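

In this assay, compound 2 and compound 4 both gave only a limit, so no step between them can be read: the limit of > 10 ug/mL in this assay, at which 4 of the 4 values shown sit.

The compounds shown leave open where any of them would actually reach half-maximal inhibition of these cells.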